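This account rests on a few compounds, and the source may have more. Where it says the series, first, only, none or still open, it means among the compounds named here.

Measured so far:
Compound 1 `O=C1Nc2ccc([N+](=O)[O-])cc2/C1=N/NC(=S)N1CCN(c2ccccc2)CC1` gives 17900 nM in a functional assay on A549 cells (Homo sapiens) for inhibition, read by MTT assay, with a stated time of 72 h; a higher number here means a weaker inhibitor, a lower number a stronger inhibitor.
Compound 2 `COc1ccc(N2CCN(C(=S)N/N=C3\C(=O)Nc4ccc(Cl)cc43)CC2)cc1` gives 7680 nM in this assay.

For the measured compounds named here, of these two numbers, compound 2 holds the lower one, and the gap to compound 1, its only neighbour, lies beyond the usual scatter. The two compounds differ from each other in more than one place, so their values show only how each one stands; no single change can be read out of the pair.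

Compound 3 `O=C1Nc2ccc(Cl)cc2/C1=N/NC(=S)N1CCN(c2ccc(F)cc2F)CC1` has not yet been measured in this assay. It differs from compound 2 in one place: 2,4-difluorophenyl in place of 4-methoxyphenyl on an amine nitrogen in a ring. Going by the values given here, no measured pair shows a change of this kind, so the expectation rests on compound 2 and on the fact that the change sits at the end of the molecule away from the shared core. The step of a 1.2-fold higher number from compound 2 to compound 3 (0.07 log units; within the scatter) is expected to be small, within the scatter or at most slightly beyond it, with no firm direction. For compound 3 the estimate is 9000 nM, with a range from 3500 nM to 25000 nM.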

Compound 3, half-maximal inhibitory concentration: 11400 nM
Compound 3: middle estimate off by 1.3-fold (0.10 log units), on the low side; measured number inside the range.
By their numbers in this assay, from the lowest: compounds 2, 3 and 1 (each within the scatter of the next, the first and the last beyond it).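

For the compounds shown here, this is the first pair that differs in one place, so a single change can now be read: the step gives a 1.5-fold higher number from compound 2 to compound 3 (0.17 log units; within the scatter) in this assay when 2,4-difluorophenyl takes the place of 4-methoxyphenyl on the amine nitrogen in the ring. At this position, three ring bonds from the ring nitrogen, the aromatic ring can carry either of these two substitution patterns, one with a hydrogen-bond acceptor and one with none, without the number moving beyond the scatter. No measurement at hand offers an explanation for this result.

The compounds shown leave open whether the same position would accept something other than a substituted phenyl ring, such as a carboxylic acid, an amine or a longer chain, since only these two groups have been compared there in a single step. Going by these compounds alone, they also leave open how much of the gap between compound 1 and the other two compounds belongs to the shared core and how much to the group on the ring nitrogen, as no single step separates these two places.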